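Extending a Side Chain on a Shared Core

The source may hold more compounds than are shown below. What is called first, only, known or untested is meant among the compounds shown, and "the series" means these compounds.

Compound 1 `CCCCNc1nc(N)nc(C)c1C` carries a methyl where its two measured relatives carry a longer chain. In an assay on HEK293 cells for agonist activity at Toll-like receptor 8 (Homo sapiens), read by spectrophotometry (a higher number here means that more compound is needed for the effect, a lower number that less compound is needed), compound 1 gives 3280 nM, the highest number among the three measured compounds. Compound 2 `CCCCNc1nc(N)nc(C)c1CCCN1CCCC1` gives 110 nM in this assay, and compound 3 `CCCCNc1nc(N)nc(C)c1CCCN1CCCCC1` gives 133 nM. The step of a 30-fold lower number from compound 1 to compound 2 (1.47 log units; beyond the scatter) shows that growing the chain with a ring-bearing amine brings the number far down, and the further step a 1.2-fold higher number from compound 2 to compound 3 (0.08 log units; within the scatter) shows that exchanging one saturated amine ring for another hardly matters.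

Compound 4 `CCCCNc1nc(N)nc(C)c1CCC(C)(C)O` grows the same methyl in a different way: 2-hydroxy-2-methylpropyl in place of hydrogen on a saturated chain carbon bound to an aromatic carbon. The entering group ends in a hydroxyl rather than in a ring nitrogen, so the measured steps bear on it only in part. Among the measured compounds shown here, both steps from compound 1 onward point the same way, toward a lower number when this chain is extended, yet no measured compound shows an extension that ends in a hydroxyl. A downward step is therefore expected for compound 4, but a more modest one than the measured amines gave; the step expected for compound 4 is a 3.6-fold lower number from compound 1 to compound 4 (0.56 log units; beyond the scatter). Compound 4 is estimated at 900 nM, within a range from 250 nM to 3500 nM.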

Compound 4, half-maximal effective concentration: 3140 nM
Estimate against measurement, compound 4: 3.5-fold (0.54 log units) below; the range from low to high includes it.
By their numbers in this assay, from the lowest: compounds 2 and 3 (each within the scatter of the next); then compounds 4 and 1 (each within the scatter of the next).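

Lengthening the chain is not enough on its own in this assay: exchanging methyl for 3-hydroxy-3-methylbutyl gives a 1.0-fold lower number from compound 1 to compound 4 (0.02 log units; within the scatter) and so leaves the number where it was, within the scatter. The earlier compounds could not separate a longer chain from the group at its end, but the two large steps here do, with a 24-fold higher number from compound 3 to compound 4 (1.37 log units; beyond the scatter) and a 29-fold higher number from compound 2 to compound 4 (1.46 log units; beyond the scatter) showing that, among these four compounds, the low numbers go only with the chains ending in a saturated amine ring, while the chain ending in a hydroxyl stays level with the methyl of compound 1. Nothing given here explains this difference between the chain ends.

The compounds shown leave open whether the ring around the nitrogen matters or the nitrogen alone is enough, a question that a chain ending in a dimethylamine or a plain primary amine would address. They also leave open how a chain ending in a carboxylic acid would read, and whether a shorter or longer chain carrying the pyrrolidin-1-yl group would keep the low number.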